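The source may hold more compounds than are shown below. What is called first, only, known or untested is meant among the compounds shown, and "the series" means these compounds.

Clearance describes how quickly the body removes a compound from the blood, and three related compounds have been tested for it in an ADME assay on the whole organism (strain Sprague-Dawley) for pharmacokinetics, with Rattus norvegicus as the target, at a dose of 5 mg/kg by the intravenous route; on this read-out higher numbers stand for fast clearance and lower numbers for slow clearance. In this assay, compound 1 (`COc1c(C(=O)Nc2ccc(NS(C)(=O)=O)cc2)cc(N2CCC(=O)NC2=O)cc1C(C)(C)C`) gives 25 mL/min/kg, compound 2 (`COc1c(/C=C/c2ccc(NS(C)(=O)=O)c(F)c2)cc(-n2ccc(=O)[nH]c2=O)cc1C(C)(C)C`) gives 6.33 mL/min/kg and compound 3 (`COc1c(/C=C/c2ccc(NS(C)(=O)=O)cc2)cc(N2CCC(=O)NC2=O)cc1C(C)(C)C`) gives 10.7 mL/min/kg. Compound 3 stands clearly apart from compound 1, whose number is higher by more than the usual scatter. Compound 3 and compound 2 cannot be told apart, as their gap lies within that scatter.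

Compound 4 (`COc1c(/C=C/c2ccc(NS(C)(=O)=O)cc2)cc(-n2ccc(=O)[nH]c2=O)cc1C(C)(C)C`) has not yet been measured. It comes from compound 3 by one swap on an aromatic carbon, para to a methoxy group and meta to a tert-butyl group: a group of 8 heavy atoms (4 carbon, 2 nitrogen, 2 oxygen; one six-membered aromatic ring with 2 hetero atoms) in place of a group of 8 heavy atoms (4 carbon, 2 nitrogen, 2 oxygen; one six-membered non-aromatic ring with 2 hetero atoms), on an aromatic carbon. In plain terms, a six-membered non-aromatic ring gives way to a six-membered aromatic ring.

Among the measured compounds shown here, no measured pair isolates this swap. The nearest guide is compound 2, which carries the same aromatic ring but also differs elsewhere, and it gives 6.33 mL/min/kg. The expected step of a 1.4-fold lower number from compound 3 to compound 4 (0.15 log units; within the scatter) is a slight fall, no larger than the scatter. For compound 4 the estimated value is 7.5 mL/min/kg, with an expected range from 3.7 mL/min/kg to 15 mL/min/kg.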

Compound 4, clearance in the Rattus norvegicus assay: 15 mL/min/kg
For compound 4 the middle estimate is 2.0-fold (0.30 log units) below the measured one, and the stated range covers the measured number.
By their numbers in the Rattus norvegicus assay, from the lowest: compounds 2, 3, 4 and 1 (each within the scatter of the next, the first and the last beyond it).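

In the Rattus norvegicus assay, where compound 3 gives 10.7 mL/min/kg and compound 4 gives 15 mL/min/kg, replacing the six-membered non-aromatic ring with the six-membered aromatic ring, at the aromatic carbon para to a methoxy group and meta to a tert-butyl group, gives a 1.4-fold higher number from compound 3 to compound 4 (0.15 log units; within the scatter), so this first clean reading of the swap cannot separate the two compounds. Hydrogen in place of fluoro on an aromatic carbon gives a 2.4-fold higher number from compound 2 to compound 4 (0.37 log units; beyond the scatter), a modest step and the only single-place change in this set of compounds whose clearance step goes beyond the usual scatter. In a physicochemical assay for solubility, at pH 7.2 (a higher number here means a more soluble compound, a lower number a less soluble compound), where compound 3 gives 10300 nM and compound 4 gives 20700 nM, the same ring swap gives a 2.0-fold higher number from compound 3 to compound 4 (0.30 log units; within the scatter), so solubility does not separate the two compounds either.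

Going by these compounds, it remains open whether other groups at this aromatic carbon, such as an amine or a carboxylic acid, would also stay within the scatter of compound 3 for clearance, and whether the fluoro step would look the same on a compound carrying the non-aromatic ring. Nothing available here accounts for the size of any of these steps.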